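Thiourea-linked pyrazole carboxamides: cell growth inhibition series

The source may hold more compounds than are shown below. What is called first, only, known or untested is meant among the compounds shown, and "the series" means these compounds.

Measured so far:
Compound 1 `Cc1ccc(NC(=S)NC(=O)c2cn(-c3ccccc3)nc2-c2ccc(F)cc2)cc1` gives 2080 nM in a functional assay on A549 cells (Homo sapiens) for inhibition, read by CCK-8 assay, with a stated time of 48 h; a higher number here means a weaker inhibitor, a lower number a stronger inhibitor.
Compound 2 `O=C(NC(=S)Nc1ccc(Cl)cc1)c1cn(-c2ccccc2)nc1-c1ccc(F)cc1` gives 2990 nM in this assay.
Compound 3 `COc1ccc(-c2nn(-c3ccccc3)cc2C(=O)NC(=S)Nc2ccc(Cl)cc2)cc1` gives 1310 nM in this assay.

Compound 3 carries the lowest of the three numbers, though its gap to compound 1 lies within the scatter. The two cores differ as set out in methoxy in place of fluoro on an aromatic carbon, and that step reads a 2.3-fold lower number from compound 2 to compound 3 (0.36 log units; beyond the scatter). Compound 4 `COc1ccc(-c2nn(-c3ccccc3)cc2C(=O)NC(=S)Nc2ccc(C)cc2)cc1` has not yet been measured in this assay. It differs from compound 3 by methyl in place of chloro on an aromatic carbon. The same change has already been made once, from compound 2 to compound 1, as methyl in place of chloro on an aromatic carbon, where it gave a 1.4-fold lower number from compound 2 to compound 1 (0.16 log units; within the scatter). For compound 4 the step is expected to be of similar size, a 1.4-fold lower number from compound 3 to compound 4 (0.14 log units; within the scatter), because the earlier step of a 1.4-fold lower number from compound 2 to compound 1 (0.16 log units; within the scatter) stayed within the scatter. Compound 4 is therefore estimated at 950 nM, with a range from 450 nM to 2000 nM.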

Compound 4, half-maximal inhibitory concentration: 1250 nM
Compound 4: middle estimate off by 1.3-fold (0.12 log units), on the low side; low and high end bracket the measured number.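

Methyl in place of chloro on the core of compound 3 reads a 1.0-fold lower number from compound 3 to compound 4 (0.02 log units; within the scatter), and this step agrees with the earlier one on the other core: the same change on two cores in this assay, a 1.4-fold lower number (0.16 log units; within the scatter) from compound 2 to compound 1 and a 1.0-fold lower number (0.02 log units; within the scatter) from compound 3 to compound 4, 1.4-fold (0.14 log units) apart, within the scatter of two such steps. Methoxy in place of fluoro, read again with methyl in place of chloro, gives a 1.7-fold lower number from compound 1 to compound 4 (0.22 log units; within the scatter), and the two readings of this change also agree: the same change on two cores in this assay, a 2.3-fold lower number (0.36 log units; beyond the scatter) from compound 2 to compound 3 and a 1.7-fold lower number (0.22 log units; within the scatter) from compound 1 to compound 4, 1.4-fold (0.14 log units) apart, within the scatter of two such steps. In this assay this shows that both changes carried over within the scatter across these four compounds, but the methyl for chloro steps are themselves within the scatter, so it does not show that a larger effect would transfer.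

Still open, on these data alone, is whether an amine or a carboxylic acid in place of chloro would behave the same way on both cores. The same applies to a longer alkoxy chain in place of methoxy.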